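The source may hold more compounds than are shown below. What is called first, only, known or untested is meant among the compounds shown, and "the series" means these compounds.

Three chalcones built on a pyrazole core were examined in a functional assay on SN12C cells (Homo sapiens) for cytotoxicity, read by sulforhodamine B assay, with a stated time of 48 h, tested at 100 uM; on this read-out lower numbers stand for a stronger effect and higher numbers for a weaker effect at the one concentration tested. Compound 1, `COc1ccc(-c2cc(/C=C/C(=O)c3ccc(N)cc3)[nH]n2)cc1`, gives -78% in this assay. Compound 2, `COc1ccc(-c2cc(/C=C/C(=O)c3ccc(N)cc3)[nH]n2)cc1OC`, gives -90% in this assay. Compound 3, `COc1cc(C(=O)/C=C/c2cc(-c3cc(OC)c(OC)c(OC)c3)n[nH]2)cc(OC)c1OC`, gives -97% in this assay; how its core differs from that of compound 2 is not broken down here. Between compound 2 and compound 1 the change is hydrogen in place of methoxy on an aromatic carbon, and it produced a number 12 percentage points higher from compound 2 to compound 1 (beyond the scatter).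

Compound 4, `COc1ccc(-c2cc(/C=C/C(=O)c3cc(OC)c(OC)c(OC)c3)[nH]n2)cc1OC`, has not yet been measured in this assay. It differs from compound 3 by hydrogen in place of methoxy on an aromatic carbon. The surroundings of the place are not identical to those in the earlier pair: here the carbon is also meta to a methoxy group, so the change is the same kind of change rather than the same one. Because the earlier pair showed a number 12 percentage points higher from compound 2 to compound 1 (beyond the scatter), a step of about the same size in the same direction is expected from compound 3 to compound 4, namely a number 11 percentage points higher from compound 3 to compound 4 (beyond the scatter). Compound 4 is therefore estimated to give -86% in this assay, expected to lie between -97% and -72%.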

Compound 4, a percentage reported as activity, at one concentration (the size of the read-out at that concentration, not a potency): -67%
Estimate against measurement, compound 4: 19 percentage points below; the measured number lies above the stated range.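

In this assay, hydrogen in place of methoxy on an aromatic carbon gave a number 30 percentage points higher from compound 3 to compound 4 (beyond the scatter). Set beside the earlier step, the direction of the change carries from one core to the other, but its size does not: the same change on two cores in this assay, a number 12 percentage points higher (beyond the scatter) from compound 2 to compound 1 and a number 30 percentage points higher (beyond the scatter) from compound 3 to compound 4, 18 percentage points apart, beyond the scatter of two such steps These two pairs show only that the size of the step depends on the surroundings in which it is made; they do not show which part of the two cores sets it, and two pairs are too few to predict the step on a further core.

The compounds shown leave open whether another group at this place, such as a hydroxyl, an ethoxy group or a carboxylic acid, would give a step like either of these two. They also leave open whether the gap of the two steps would hold at a concentration other than the single one used in this assay.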